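Cyclohexyl Gives Way to 3,4-Dichlorophenyl

The source may report more compounds than this note shows. Statements on the series, on what has been measured and on what is new or still open speak of the compounds shown alone.

Compound 3 `O=C(Nc1cccc(CNc2nccnc2Cl)c1)NC1CCCCC1` stands at > 40000 nM in a functional assay on T-24 cells (Homo sapiens) for antiproliferative activity, read by MTT assay, with a stated time of 48 h (on this read-out higher numbers stand for weaker inhibition and lower numbers for stronger inhibition), as a limit of the assay and not a number. Compound 1 `CCOc1ccc(NC(=O)Nc2cccc(CNc3nccnc3Cl)c2)cc1` gives 9080 nM here. Compound 2 `O=C(Nc1cccc(CNc2nccnc2Cl)c1)Nc1ccc(Cl)cc1Cl` gives 5740 nM here, and a 1.6-fold lower number from compound 1 to compound 2 (0.20 log units; within the scatter) separates these two. Compound 4 `O=C(Nc1cccc(CNc2nccnc2Cl)c1)Nc1ccc(Cl)c(Cl)c1` differs from compound 3 by one exchange 3,4-dichlorophenyl in place of cyclohexyl on an amide-type nitrogen with 3,4-dichlorophenyl in place of cyclohexyl on an amide-type nitrogen. The closest measured changes run the opposite way, namely an at least 4.4-fold higher number from compound 1 to compound 3 (0.64 log units; beyond the scatter) and an at least 6.9-fold higher number from compound 2 to compound 3 (0.84 log units; beyond the scatter) for the two aromatic compounds. Reversed, they point to a lower number in this assay with a size known only as a bound. The expected step is an at least 6.1-fold lower number from compound 3 to compound 4 (0.78 log units; beyond the scatter) on that reasoning. Compound 4 is expected at 6500 nM within an estimated range of 2500 nM to 16000 nM when measured.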

Compound 4, half-maximal inhibitory concentration: 5210 nM
The estimate for compound 4 lay 1.2-fold (0.10 log units) above the measured number; low and high end bracket the measured number.
By their numbers in this assay, from the lowest: compounds 4, 2 and 1 (each within the scatter of the next). At a limit, above all of these: compound 3.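

In this assay, 3,4-dichlorophenyl joins the other aromatic groups in standing clear of cyclohexyl on the amide-type nitrogen (an at least 7.6-fold lower number from compound 3 to compound 4 (0.88 log units; beyond the scatter)). From the compounds shown here alone, compound 3 stands at a limit of the assay, not a number, so the true size of this step stays unknown: (the limit of > 40000 nM in this assay, at which 1 of the 4 values shown sits). Among the aromatic groups, no change can be told from the scatter (a 1.1-fold lower number from compound 2 to compound 4 (0.04 log units; within the scatter); a 1.7-fold lower number from compound 1 to compound 4 (0.24 log units; within the scatter)).

Going by these compounds, whether a phenyl ring carrying an amine or a carboxylic acid would keep this level remains open. So does the effect of a pyridine ring or a simple benzyl group at this position.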